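The source may hold more compounds than are shown below. What is called first, only, known or untested is meant among the compounds shown, and "the series" means these compounds.

Of the compounds shown here, two have been tested so far in a functional assay on HCT-116 cells (Homo sapiens) for antiproliferative activity, read by MTT assay, with a stated time of 72 h; a lower number here means a stronger inhibitor, a higher number a weaker inhibitor. In this test compound 1 (`Cc1ccc(-c2cn(C[C@H](O)[C@H]3OC(=O)C(OCc4ccccc4)=C3OCc3ccccc3)nn2)cc1`) gives > 100000 nM, a limit of the assay and not a number. Compound 2 (`O=C1O[C@H]([C@@H](O)Cn2ccnn2)C(OCc2ccccc2)=C1OCc1ccccc1`) gives > 100000 nM, also a limit and not a number. Compound 2 therefore stands at the limit of > 100000 nM in this assay, at which 2 of the 2 values shown sit. Within the data shown here, the only measured change, hydrogen in place of 4-methylphenyl on an aromatic carbon, is a step that the two limits leave unreadable from compound 1 to compound 2. Compound 3 (`O=C1O[C@H]([C@@H](O)Cn2cc(CCO)nn2)C(OCc2ccccc2)=C1OCc1ccccc1`) places 2-hydroxyethyl on that kind of carbon of the triazole in compound 2, in place of hydrogen: 2-hydroxyethyl in place of hydrogen on an aromatic carbon. Neither the unreadable step nor the two limits give a measured size or direction to build on, so the expectation is that compound 3 remains inactive in this assay. The expected a number no higher from compound 2 to compound 3 (the limit leaves the size open) is no larger than the scatter. For compound 3 the estimated value is 100000 nM, with an expected range of 30000 nM to 200000 nM.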

Compound 3, half-maximal inhibitory concentration: 72700 nM
For compound 3 the middle estimate is 1.4-fold (0.14 log units) above the measured one; low and high end bracket the measured number.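

In this assay, among these compounds, compound 3 gives 72700 nM, the first value at this position that is a number and not a limit. On this aromatic carbon of the five-membered ring, 2-hydroxyethyl in place of hydrogen gives an at least 1.3-fold lower number from compound 2 to compound 3 (0.13 log units; that floor lies within the scatter), and 2-hydroxyethyl in place of 4-methylphenyl gives an at least 1.3-fold lower number from compound 1 to compound 3 (0.13 log units; that floor lies within the scatter); both are floors only, so neither change is shown to go beyond the scatter, though the true sizes could be larger. The other two compounds remain at the limit of the assay, which is a limit and not a number: the limit of > 100000 nM in this assay, at which 2 of the 3 values shown sit.

From the compounds shown here alone, whether a longer chain, an amine or a carboxylic acid on this carbon would lower the number further remains open. Also open, going by these compounds, is whether a plain ethyl group, without the hydroxyl, would give a similar value.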